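The source may hold more compounds than are shown below. What is called first, only, known or untested is meant among the compounds shown, and "the series" means these compounds.

Measured in an assay for binding affinity to Apoptosis regulator Bcl-2 (Homo sapiens), read by fluorescence polarization, with a stated time of 2 h; on this read-out higher numbers stand for weaker inhibition and lower numbers for stronger inhibition:
compound 1 `Cc1c(C(=O)NCCCN2CCN(C)CC2)c(-c2cccc(N3CCN(c4ccc(NS(=O)(=O)c5cccc(S(=O)(=O)C6CC6)c5)cc4)CC3)c2)c(-c2ccc(Cl)cc2)n1C` gives 218 nM
compound 2 `CCn1c(C)c(C(=O)O)c(-c2cccc(N3CCN(c4ccc(NS(=O)(=O)c5ccc(N[C@H](CCN6CCC(O)CC6)CSc6ccccc6)c(S(=O)(=O)C(F)(F)F)c5)cc4)CC3)c2)c1-c1ccc(Cl)cc1` gives 1.2 nM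
compound 3 `Cc1c(C(=O)NCCCN2CCN(C)CC2)c(-c2cccc(N3CCN(c4ccc(NS(=O)(=O)c5cccc(OC(F)(F)F)c5)cc4)CC3)c2)c(-c2ccc(Cl)cc2)n1C` gives 197 nM

Compound 3 stands second highest of the three numbers; its nearest neighbour is compound 1, within the scatter, while compound 2 lies far lower, beyond the scatter. Compound 4 `Cc1c(C(=O)NCCCN2CCN(C)CC2)c(-c2cccc(N3CCN(c4ccc(NS(=O)(=O)c5cccc(S(=O)(=O)C(F)(F)F)c5)cc4)CC3)c2)c(-c2ccc(Cl)cc2)n1C` differs from compound 3 in one place: (trifluoromethyl)sulfonyl in place of trifluoromethoxy on an aromatic carbon. For the measured compounds named here, the one step that bears on this is a 1.1-fold lower number from compound 1 to compound 3 (0.04 log units; within the scatter), where exchanging one substituent at this position for another left the number within the scatter. Compound 2 also carries a (trifluoromethyl)sulfonyl group but differs in several other places, so its value says little here. For compound 4 a step of a 1.0-fold lower number from compound 3 to compound 4 (0.02 log units; within the scatter) is therefore expected, within the scatter. Compound 4 is estimated at 190 nM, in the range 90 nM to 400 nM.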

Compound 4, inhibition constant: 39.2 nM
For compound 4 the middle estimate is 4.8-fold (0.69 log units) above the measured one, outside the stated range (below it).
By their numbers in this assay, from the lowest: compound 2; then compound 4; then compounds 3 and 1 (each within the scatter of the next).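

On an aromatic carbon of this ring the substituent does matter in this assay: (trifluoromethyl)sulfonyl in place of trifluoromethoxy gives a 5.0-fold lower number from compound 3 to compound 4 (0.70 log units; beyond the scatter) and trifluoromethyl in place of cyclopropyl on the sulfonyl sulfur gives a 5.6-fold lower number from compound 1 to compound 4 (0.75 log units; beyond the scatter). The earlier flat step therefore did not mean that the position tolerates any change. A sulfonyl alone does not set the number, since compound 1 also carries one. No measurement here accounts for the difference. Still open, on these data alone, is how an amine, a carboxylic acid or a longer fluoroalkyl chain on the sulfonyl sulfur would compare.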